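Replacing the methylphenyl arm with pyridinyl: an expectation

The compounds below may be only part of what the source reports. "The series", "measured", "known", "first", "only" and "open" are said of these compounds alone.

Measured so far:
Compound 1 `COc1ccc(/C=C2\S/C(=N\c3csc(-c4ccc(Cl)cc4)c3)NC2=O)cc1`: 3800 nM
Compound 2 `Cc1ccc(/C=C2\S/C(=N\c3csc(-c4ccc(Cl)cc4)c3)NC2=O)cc1`: 6400 nM

For the measured compounds named here, in a functional assay on HT-29 cells (Homo sapiens) for cytotoxicity, read by MTT assay, with a stated time of 72 h (a higher number here means a weaker inhibitor, a lower number a stronger inhibitor), compound 2 gives the higher of the two numbers, but its only neighbour, compound 1, sits close: the step of a 1.7-fold higher number from compound 1 to compound 2 (0.23 log units; within the scatter) is within the scatter, so the two compounds cannot be ordered.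

Compound 3 `O=C1N/C(=N/c2csc(-c3ccc(Cl)cc3)c2)S/C1=C\c1ccccn1` differs from compound 2 in that (pyridin-2-yl in place of 4-methylphenyl on a double-bonded chain carbon bound to a double-bonded ring carbon). Going by the values given here, the one measured step swapped a substituent on that ring and moved the number hardly at all; here the ring itself is exchanged for one bearing a nitrogen, a larger change on which the single measured step bears only loosely. Among the compounds with values here, with no directly comparable precedent, compound 3 is expected to stay near compound 2, with a wide range to reflect the uncertainty. The expected step amounts to a 1.3-fold lower number from compound 2 to compound 3 (0.11 log units; within the scatter). Compound 3 is therefore estimated at 5000 nM, between 1500 nM and 20000 nM.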

Compound 3, half-maximal inhibitory concentration: 11500 nM
Compound 3: the middle estimate sits 2.3-fold (0.36 log units) below what was measured; the range from low to high includes it.
By their numbers in this assay, from the lowest: compounds 1, 2 and 3 (each within the scatter of the next, the first and the last beyond it).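

In this assay, exchanging 4-methylphenyl for pyridin-2-yl on a double-bonded chain carbon bound to a double-bonded ring carbon gives a 1.8-fold higher number from compound 2 to compound 3 (0.25 log units; within the scatter), so the whole ring can be replaced here without a step that can be read. Against the 4-methoxyphenyl ring, the same exchange gives a 3.0-fold higher number from compound 1 to compound 3 (0.48 log units; beyond the scatter), a modest step and the only one so far beyond the scatter, which makes this the only pair of the three that can be ordered. Nothing available explains this difference between compound 1 and compound 3.

On these data alone, it remains open how a plain phenyl, pyridin-3-yl or pyridin-4-yl would compare at this position. Also open, as far as these compounds go, is whether an amine or a carboxylic acid on this ring would move the number further than any step seen here.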